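Swapping the fluorophenyl for a trifluoromethylphenyl carbamate ester

The source may report more compounds than this note shows. Statements on the series, on what has been measured and on what is new or still open speak of the compounds shown alone.

Measured so far:
compound 1 `COc1ccc(-c2cnn(C)c2NC(=O)O[C@H](C)c2ccccc2)cc1`; in an in vitro functional assay on chem-1 cells for antagonist activity at lysophosphatidic acid receptor 3 (Homo sapiens), read by FLIPR and calcium flux, with stated times of 30 min and 100 s (on this read-out higher numbers stand for weaker inhibition and lower numbers for stronger inhibition), compound 1 gives > 30000 nM, which is a limit rather than a number.
compound 2 `C[C@@H](OC(=O)Nc1c(-c2ccc(-c3ccc(C4(C(=O)O)CC4)cc3)cc2)cnn1C)c1ccccc1`; in this assay compound 2 gives 8340 nM.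
compound 3 `CC(OC(=O)Nc1c(-c2ccc(-c3ccc(C4(C(=O)O)CC4)cc3)cc2)cnn1C)c1ccc(F)cc1`; in this assay compound 3 gives 8260 nM.

Compound 3 holds the lowest of the two numbers, with compound 2 within the scatter of it, while compound 1 gives only a limit. Compound 4 `C[C@@H](OC(=O)Nc1c(-c2ccc(-c3ccc(C4(C(=O)O)CC4)cc3)cc2)cnn1C)c1cccc(C(F)(F)F)c1` differs from compound 3 by a group of 12 heavy atoms (9 carbon, 3 fluorine; one six-membered aromatic ring of carbon only) in place of a group of 9 heavy atoms (8 carbon, 1 fluorine; one six-membered aromatic ring of carbon only), on an oxygen next to a carbonyl group. The nearest measured step also changed the group on that oxygen: a 1.0-fold lower number from compound 2 to compound 3 (0.00 log units; within the scatter). The other step, an at least 3.5-fold lower number from compound 1 to compound 2 (0.55 log units; beyond the scatter), concerns a different part of the shared core. The expected step is therefore a 1.0-fold higher number from compound 3 to compound 4 (0.01 log units; within the scatter), nothing beyond the scatter. Compound 4 is estimated at 8500 nM, with a range from 3000 nM to 25000 nM.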

Compound 4, half-maximal inhibitory concentration: 478 nM
Beside the measured number, compound 4's estimate is 18-fold (1.25 log units) above it; measured number below the stated range.
By their numbers in this assay, from the lowest: compound 4; then compounds 3 and 2 (each within the scatter of the next). At a limit, above all of these: compound 1.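

In this assay the group on the oxygen next to a carbonyl group proves able to move the number, with a 17-fold lower number from compound 3 to compound 4 (1.24 log units; beyond the scatter) and a 17-fold lower number from compound 2 to compound 4 (1.24 log units; beyond the scatter) against only a 1.0-fold lower number from compound 2 to compound 3 (0.00 log units; within the scatter) for the fluorine. So the flat result from the earlier pair did not mean that this position tolerates any change without effect: trifluoromethyl in place of hydrogen on an aromatic carbon moves the number where fluorine did not. Whether a nitrile or a chlorine in that place would do the same stays open, and nothing shown here explains the gain.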